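From One Reading Toward Compound 3

This account rests on a few compounds, and the source may have more. Where it says the series, first, only, none or still open, it means among the compounds named here.

Among the compounds with values here, in a physicochemical assay for lipophilicity, read by HPLC, in phosphate buffer, measured as octanol-water partition, at pH 7.4, tested at 100 uM (a higher number here means a more lipophilic compound, a lower number a more polar compound), compound 1 (`CCOc1cc(C)c(-c2cccc(COc3ccc(NCC(=O)O)c(F)c3)c2)c(C)c1`) offers no number ("not determined" (no result reported)), and compound 2 (`CC(C)c1ccccc1-c1cccc(CNc2ccc(OCC(=O)O)c(F)c2)c1`) reads 3.45 as the only value available. Compound 3 (`CCOc1ccc(-c2cccc(CNc3ccc(OCC(=O)O)c(F)c3)c2)c(C)c1`) carries 4-ethoxy-2-methylphenyl in place of 2-isopropylphenyl on an aromatic carbon, meta to a large group (4-ethoxy-2-methylphenyl in place of 2-isopropylphenyl on an aromatic carbon). Within the data shown here, no measured pair shows this change, so in this assay only a small downward step is expected (a number 0.15 log units lower from compound 2 to compound 3 (within the scatter)), possibly none beyond the scatter. The estimated value for compound 3 is 3.3 with an expected range from 2.9 to 3.7 on this scale.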

Compound 3, distribution coefficient: 2.83
Compound 3: the middle estimate sits 0.47 log units above what was measured, and the stated range ends above it.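

In this assay, within the data shown here, 4-ethoxy-2-methylphenyl in place of 2-isopropylphenyl on this aromatic carbon gives a number 0.62 log units lower from compound 2 to compound 3 (beyond the scatter), the only step available on this scale. The position is therefore not silent: exchanging one substituted phenyl for another, with the rest of the structure unchanged, moves the reading. Nothing measured here accounts for the size of this step. From the compounds shown here alone, whether the ethoxy group, the methyl group or the loss of isopropyl carries the step stays open. So does how a methoxy group or a primary amine at this place would read.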